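Fluorophenyl swaps and a chlorine newcomer

The source may report more compounds than this note shows. Statements on the series, on what has been measured and on what is new or still open speak of the compounds shown alone.

Values in an ADME assay on HUVEC cells (Homo sapiens) for inhibition, read by CCK-8 assay, with a stated time of 24 h, in the presence of a further agent that is not named here (a higher number here means a weaker inhibitor, a lower number a stronger inhibitor), for the measured compounds
Compound 1 `O=C1Nc2ccccc2/C1=C/c1ccc(-c2cn(-c3ccccc3F)nn2)cc1` gives 19300 nM
Compound 2 `O=C1Nc2ccccc2/C1=C/c1ccc(-c2cn(-c3cccc(F)c3)nn2)cc1` gives > 20000 nM (a limit, not a number)
Compound 3 `O=C1Nc2ccccc2/C1=C/c1ccc(-c2cn(-c3ccc(F)cc3)nn2)cc1` gives 14700 nM

Within the data shown here, compound 3 stands level with the only other compound that gives a real number, with a 1.3-fold lower number from compound 1 to compound 3 (0.12 log units; within the scatter) as the gap between them. Compound 2 gives only a limit in this assay and that limit is > 20000 nM with no real number behind it. Both an at least 1.0-fold higher number from compound 1 to compound 2 (0.01 log units; that floor lies within the scatter) and an at least 1.3-fold lower number from compound 2 to compound 3 (0.13 log units; that floor lies within the scatter) are floors only, and neither goes beyond the scatter.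

Going from compound 3 to compound 4 `O=C1Nc2ccccc2/C1=C/c1ccc(-c2cn(-c3cccc(Cl)c3)nn2)cc1` puts 3-chlorophenyl in place of 4-fluorophenyl on an aromatic nitrogen and no measured step swaps fluorine for chlorine. The closest guide is compound 2, with 3-fluorophenyl, and an at least 1.3-fold lower number from compound 2 to compound 3 (0.13 log units; that floor lies within the scatter) hints only weakly at a higher number for compound 4. The expected change is a 1.1-fold higher number from compound 3 to compound 4 (0.04 log units; within the scatter) and so no step beyond the scatter is expected. It is also possible that compound 4 reaches the limit of > 20000 nM in this assay, at which 1 of the 3 values shown sits, and returns no real number. For compound 4 the estimated value is 16000 nM with an expected range from 8000 nM to 30000 nM as the likely span.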

Compound 4, half-maximal inhibitory concentration: > 20000 nM
Compound 4: a limit, no number; the forecaster's own chance of this, stated with the estimate: 35%; at least 1.2-fold (0.09 log units) between middle value and limit.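

In this assay compound 4 gives only a limit, not a real number, and compound 2 gives a limit too: the limit of > 20000 nM in this assay, at which 2 of the 4 values shown sit.

From the compounds shown here alone, on this aromatic nitrogen, then, the 3-chlorophenyl group gives the same kind of result as the 3-fluorophenyl group of compound 2, while the 2-fluorophenyl and 4-fluorophenyl groups of compounds 1 and 3 still return real numbers, though the size of any difference stays unknown. The two readable steps are floors only, with an at least 1.3-fold higher number from compound 3 to compound 4 (0.13 log units; that floor lies within the scatter) and an at least 1.0-fold higher number from compound 1 to compound 4 (0.01 log units; that floor lies within the scatter), so neither shows a change beyond the scatter, and the direct swap of chloro for fluoro joins two limits and cannot be read.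

The compounds shown leave open whether any group on this aromatic nitrogen can move the number clearly away from the values seen so far, since every step that can be read stays within the scatter. They also leave open how a phenyl ring carrying an amine or a carboxylic acid, or a longer chain in place of the phenyl ring, would read in this assay.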